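The source may hold more compounds than are shown below. What is called first, only, known or untested is meant among the compounds shown, and "the series" means these compounds.

The series shares one core, carried by compound 1 `COc1cc2c(Nc3cccc(C#N)c3)ncnc2cc1OCCCN1CCC(C)CC1`, compound 2 `COc1cc2c(Nc3cccc(C#N)c3)ncnc2cc1OCCCN1CCN(C)CC1` and compound 3 `COc1cc2c(Nc3ccccc3C#N)ncnc2cc1OCCCN1CCC(C)CC1`. In a functional assay on SH-SY5Y cells (Homo sapiens) for antiproliferative activity, read by MTT assay, with a stated time of 72 h (on this read-out higher numbers stand for weaker inhibition and lower numbers for stronger inhibition), compound 1 gives 7330 nM. Compound 2 differs from compound 1 by 4-methylpiperazin-1-yl in place of 4-methylpiperidin-1-yl on a saturated chain carbon, three bonds along the chain from an oxygen on an aromatic ring; in this assay compound 2 gives 6890 nM, and the step is a 1.1-fold lower number from compound 1 to compound 2 (0.03 log units; within the scatter). Compound 3 differs from compound 1 by 2-cyanophenyl in place of 3-cyanophenyl on a nitrogen on an aromatic ring; in this assay compound 3 gives 29000 nM, and the step is a 4.0-fold higher number from compound 1 to compound 3 (0.60 log units; beyond the scatter), leaving compound 3 with the highest number of the three. Compound 4 `COc1cc2c(Nc3ccccc3C#N)ncnc2cc1OCCCN1CCN(C)CC1` has not yet been measured. Going by the values given here, it differs from compound 3 by 4-methylpiperazin-1-yl in place of 4-methylpiperidin-1-yl on a saturated chain carbon, three bonds along the chain from an oxygen on an aromatic ring, the same change as the one between compound 1 and compound 2, at the same place. Because that earlier step a 1.1-fold lower number from compound 1 to compound 2 (0.03 log units; within the scatter) stayed within the scatter, a step of comparable size is expected from compound 3 to compound 4, namely a 1.1-fold lower number from compound 3 to compound 4 (0.03 log units; within the scatter). On this basis compound 4 is expected to give about 27000 nM in this assay, with the result most likely falling between 12000 nM and 60000 nM.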

Compound 4, half-maximal inhibitory concentration: 32400 nM
Beside the measured number, compound 4's estimate is 1.2-fold (0.08 log units) below it; the measured number falls inside the stated range.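

In this assay, 4-methylpiperazin-1-yl in place of 4-methylpiperidin-1-yl carries over from the 3-cyanophenyl pair to the 2-cyanophenyl pair, with a 1.1-fold higher number from compound 3 to compound 4 (0.05 log units; within the scatter) matching the earlier step: the same change on two cores in this assay, a 1.1-fold lower number (0.03 log units; within the scatter) from compound 1 to compound 2 and a 1.1-fold higher number (0.05 log units; within the scatter) from compound 3 to compound 4, 1.2-fold (0.08 log units) apart, within the scatter of two such steps

The reverse reading also holds, as 2-cyanophenyl in place of 3-cyanophenyl gives a 4.7-fold higher number from compound 2 to compound 4 (0.67 log units; beyond the scatter) on the 4-methylpiperazin-1-yl compounds, matching the step on the 4-methylpiperidin-1-yl compounds: the same change on two cores in this assay, a 4.0-fold higher number (0.60 log units; beyond the scatter) from compound 1 to compound 3 and a 4.7-fold higher number (0.67 log units; beyond the scatter) from compound 2 to compound 4, 1.2-fold (0.08 log units) apart, within the scatter of two such steps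

Together these show that, in these four compounds, each change gives the same result on either core, so the two changes read as independent of each other; they do not show that this holds for any other group, and each comparison rests on one pair per core in one cell assay.

The compounds shown leave open whether a 4-cyanophenyl or a 3-chlorophenyl on the same nitrogen would follow the same pattern. Also open, going by these compounds, is whether a morpholin-4-yl group or a shorter 2-(4-methylpiperazin-1-yl)ethyl chain would leave the numbers equally unmoved.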